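The source may report more compounds than this note shows. Statements on the series, on what has been measured and on what is new or still open speak of the compounds shown alone.

Compound 1 `CC(C)C[C@H](N)c1cc(C(F)(F)F)ccc1N1CCN(C(=O)COc2ccc(Cl)cc2)CC1` and compound 2 `CC(C)C[C@H](N)c1cc(C(F)(F)F)ccc1N1CCN(C(=O)COc2ccc([N+](=O)[O-])cc2)CC1` share one core and differ only in a single group on the aromatic ring at the far end of the molecule. In an assay on HEK293 cells for displacement of a labelled ligand from Melanocortin receptor 4 (Homo sapiens) (on this read-out higher numbers stand for weaker inhibition and lower numbers for stronger inhibition), compound 1 gives 2900 nM, and compound 2 gives 3100 nM. Within the data shown here, the one step measured so far, a 1.1-fold higher number from compound 1 to compound 2 (0.03 log units; within the scatter), shows that this exchange left the number essentially unchanged; the two values lie within the scatter of each other, so neither compound can be called the stronger one.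

Compound 3 `Cc1ccc(CC(C)C(=O)N2CCN(c3ccc(C(F)(F)F)cc3[C@@H](N)CC(C)C)CC2)cc1C` departs from compound 2 at a different spot: 1-(3,4-dimethylbenzyl)ethyl in place of (4-nitrophenoxy)methyl on a carbonyl carbon. This change removes the whole group attached to the carbonyl carbon, including the ring that carried the nitro group, and replaces it with a group that carries no hydrogen-bond acceptor at all. Among the measured compounds shown here, no measured step bears directly on such a replacement; the step from compound 1 to compound 2 only touched one group on a ring that is now gone, and it stayed within the scatter. The expectation is therefore uncertain in both directions, and compound 3 is estimated at 3000 nM in this assay, with a range from 600 nM to 15000 nM. The expected step is a 1.0-fold lower number from compound 2 to compound 3 (0.01 log units; within the scatter).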

Compound 3, inhibition constant: 240 nM
The estimate for compound 3 lay 13-fold (1.10 log units) above the measured number; the measured number lies below the stated range.
By their numbers in this assay, from the lowest: compound 3; then compounds 1 and 2 (each within the scatter of the next).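

The group on the carbonyl carbon turns out to matter far more than the earlier exchange suggested. In this assay, the change from chloro to nitro gave a 1.1-fold higher number from compound 1 to compound 2 (0.03 log units; within the scatter) and stayed within the scatter, whereas bringing in 1-(3,4-dimethylbenzyl)ethyl gives a 13-fold lower number from compound 2 to compound 3 (1.11 log units; beyond the scatter) and likewise gives a 12-fold lower number from compound 1 to compound 3 (1.08 log units; beyond the scatter) and so moves well beyond it. Both large steps swap a group of the same heavy-atom count and with one aromatic ring for another, but the entering group is all carbon and has no hydrogen-bond acceptors, and nothing measured here explains why the number falls.

The replacement alters several features at once, so the compounds shown leave open whether the drop follows from the loss of the ether oxygen, the two ring methyl groups, the branching methyl group, or their combination. A plain benzyl group on the carbonyl carbon would begin to separate these features, while an amine or a carboxylic acid on the ring of the entering group would show how much change this position accepts.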